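A Second Methyl on the Oxazole Ring

This account rests on a few compounds, and the source may have more. Where it says the series, first, only, none or still open, it means among the compounds named here.

Of the compounds shown here, three sharing one core have been measured in a functional assay on HepG2 cells (Homo sapiens) for antiproliferative activity, read by sulforhodamine B assay, with a stated time of 48 h; a lower number here means a stronger inhibitor, a higher number a weaker inhibitor. Compound 1 `CC(=O)NS(=O)(=O)c1ccc(N/C(S)=N\c2ccnc3cc(C(F)(F)F)ccc23)cc1` gives 28400 nM, compound 2 `N=C(N)NS(=O)(=O)c1ccc(N/C(S)=N\c2ccnc3cc(C(F)(F)F)ccc23)cc1` gives 33500 nM, and compound 3 `Cc1cc(NS(=O)(=O)c2ccc(N/C(S)=N\c3ccnc4cc(C(F)(F)F)ccc34)cc2)on1` gives 28500 nM. Compound 3 holds the second highest of these three numbers, but the gaps are small: a 1.0-fold higher number from compound 1 to compound 3 (0.00 log units; within the scatter), a 1.2-fold lower number from compound 2 to compound 3 (0.07 log units; within the scatter) and a 1.2-fold higher number from compound 1 to compound 2 (0.07 log units; within the scatter). Whatever group sits on the sulfonamide nitrogen, whether acetyl, the group of compound 2 or 3-methyl-1,2-oxazol-5-yl, the number is the same within the scatter.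

Compound 4 `Cc1noc(NS(=O)(=O)c2ccc(N/C(S)=N\c3ccnc4cc(C(F)(F)F)ccc34)cc2)c1C` differs from compound 3 by methyl in place of hydrogen on an aromatic carbon, so that 3-methyl-1,2-oxazol-5-yl becomes 3,4-dimethyl-1,2-oxazol-5-yl. For the measured compounds named here, no measured step adds a methyl to this ring; the three steps swap the whole group on the sulfonamide nitrogen, and all stayed within the scatter. A single methyl on the ring is a smaller change than any of those, so compound 4 is expected to shift by a 1.1-fold higher number from compound 3 to compound 4 (0.02 log units; within the scatter), nothing beyond the scatter. Compound 4 is therefore estimated at 30000 nM, within a range from 14000 nM to 65000 nM.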

Compound 4, half-maximal inhibitory concentration: 36800 nM
For compound 4 the middle estimate is 1.2-fold (0.09 log units) below the measured one; low and high end bracket the measured number.
By their numbers in this assay, from the lowest: compounds 1, 3, 2 and 4 (each within the scatter of the next).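

Adding a methyl to this aromatic carbon, next to the ring atom that bears a large group, is the first direct test of this position, and in this assay the change stays within the scatter (a 1.3-fold higher number from compound 3 to compound 4 (0.11 log units; within the scatter)). The complete 3,4-dimethyl-1,2-oxazol-5-yl group also stays within the scatter when set against the two non-ring groups on the sulfonamide nitrogen (a 1.1-fold higher number from compound 2 to compound 4 (0.04 log units; within the scatter); a 1.3-fold higher number from compound 1 to compound 4 (0.11 log units; within the scatter)), so the four compounds remain indistinguishable in this assay. No measurement available here offers an explanation for this result.

Going by these compounds, whether anything larger than methyl on this carbon, such as an ethyl, a phenyl or a longer chain, would move the number beyond the scatter remains open. The same holds for an amine or a carboxylic acid at this position.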